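The source may hold more compounds than are shown below. What is called first, only, known or untested is meant among the compounds shown, and "the series" means these compounds.

Three compounds that share one core have been run through an ADME assay on microsomes from liver (Homo sapiens) for metabolic stability, read by LC-MS, tested at 1 uM; on this read-out lower numbers stand for slow clearance and higher numbers for fast clearance. Compound 1 `NC(=O)C1CCN(Cc2ccc([C@H]3CC[C@]4(CC3)OOC3(O4)C4CC5CC(C4)CC3C5)cc2)CC1` gives 10 mL.min-1.g-1. Compound 2 `CC1(C)CC(O)(COc2ccc([C@H]3CC[C@]4(CC3)OOC3(O4)C4CC5CC(C4)CC3C5)cc2)CC(C)(C)N1` gives 14 mL.min-1.g-1. Compound 3 `NCCCCOc1ccc([C@H]2CC[C@]3(CC2)OOC2(O3)C3CC4CC(C3)CC2C4)cc1` returns only a limit of the assay, < 7 mL.min-1.g-1, so its exact number is not known. On the numbers shown, compound 3 stands at the limit of < 7 mL.min-1.g-1 in this assay, at which 1 of the 3 values shown sits. The step of an at least 1.4-fold lower number from compound 1 to compound 3 (0.15 log units; that floor lies within the scatter) and the step of an at least 2.0-fold lower number from compound 2 to compound 3 (0.30 log units; that floor lies within the scatter) each have a floor that lies within the usual scatter, so neither shows a change that can be trusted.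

Compound 4 `c1cc([C@H]2CC[C@]3(CC2)OOC2(O3)C3CC4CC(C3)CC2C4)ccc1OCCOC1CCNCC1` has not yet been measured. It differs from compound 3 in one place: (piperidin-4-yl)oxy in place of 2-aminoethyl on a saturated chain carbon, two bonds along the chain from an oxygen on an aromatic ring. The chain that carries the amine thus grows longer and acquires a ring. Going by the values given here, none of the measured steps covers a change of this kind; they only show that the move from the side chains of compound 1 or compound 2 to the 4-aminobutoxy chain of compound 3 did not raise the number.

With compound 3 at a limit and no step larger than the scatter, the expected step of an at least 1.2-fold higher number from compound 3 to compound 4 (0.10 log units; that floor lies within the scatter) is small. Compound 4 is therefore estimated at about 9 mL.min-1.g-1, within a range from 4 mL.min-1.g-1 to 20 mL.min-1.g-1.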

Compound 4, intrinsic clearance in microsomes: < 7 mL.min-1.g-1
Compound 4 was reported as a limit (the forecaster's own chance of this, stated with the estimate: 35%); at least 1.2-fold (0.10 log units) between middle value and limit.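

In this assay, compound 4 also returns only a limit, < 7 mL.min-1.g-1, so the chain carrying the (piperidin-4-yl)oxy group ends up at the same limit as the 4-aminobutoxy chain of compound 3: the limit of < 7 mL.min-1.g-1 in this assay, at which 2 of the 4 values shown sit.

Compound 3 and compound 4 are both limits, and the step between them cannot be read. The other two steps, an at least 2.0-fold lower number from compound 2 to compound 4 (0.30 log units; that floor lies within the scatter) and an at least 1.4-fold lower number from compound 1 to compound 4 (0.15 log units; that floor lies within the scatter), show no change that can be trusted either, but the result still adds something new: at this position, a longer chain with a six-membered ring containing one hetero atom leaves the number at the limit.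

On these data alone, how far under the limit compound 3 and compound 4 really lie remains unknown, and so does any true difference between them. As far as these compounds go, it also remains open whether the number would stay at the limit with a carboxylic acid in place of the amine at the end of the chain, or with a still longer chain.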